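The source may report more compounds than this note shows. Statements on the series, on what has been measured and on what is new or still open speak of the compounds shown alone.

In a functional assay on HEK293 cells for positive allosteric modulation of metabotropic glutamate receptor 5 (Homo sapiens), read by FLIPR and calcium flux (a lower number here means that less compound is needed, a higher number that more compound is needed for the effect), compound 2 `O=C(COCc1ccccn1)N1CCN(c2ccc(Cl)cc2Cl)CC1` gives 310 nM, the lowest of the two numbers in hand; compound 1 `O=C(COCc1ccncc1)N1CCN(c2ccc(Cl)cc2)CC1` gives 1300 nM, a higher number beyond the scatter. Compound 3 `N#Cc1ccc(COCC(=O)N2CCN(c3ccc(Cl)cc3Cl)CC2)s1` has not yet been measured. It differs from compound 2 in one place: 5-cyanothiophen-2-yl in place of pyridin-2-yl on a saturated chain carbon bound to an oxygen on a saturated carbon. Within the data shown here, no step between two measured compounds bears on this change, so the expectation rests on compound 2 alone. The step of a 1.1-fold lower number from compound 2 to compound 3 (0.04 log units; within the scatter) is expected to be small, within the scatter, in no sure direction. Compound 3 is therefore estimated at 280 nM, with a range from 80 nM to 900 nM.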

Compound 3, half-maximal effective concentration: 210 nM
Estimate against measurement, compound 3: 1.3-fold (0.12 log units) above; low and high end bracket the measured number.
By their numbers in this assay, from the lowest: compounds 3 and 2 (each within the scatter of the next); then compound 1.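

In this assay, among these compounds, a 1.5-fold lower number from compound 2 to compound 3 (0.17 log units; within the scatter) gives the first reading of a change on a saturated chain carbon bound to an oxygen on a saturated carbon. It shows that, with the rest of compound 2 held fixed, 5-cyanothiophen-2-yl can take the place of pyridin-2-yl and keep the number within the scatter. No measurement in hand gives a reason for this.

Going by these compounds, the nitrile and the thiophene ring enter together, so their separate contributions remain open. Also open, on these data alone, is whether plain thiophen-2-yl, or a carboxylic acid or an amine in place of the nitrile, would hold the number.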